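Adding a Methoxy Group to Compound 3

The source may hold more compounds than are shown below. What is called first, only, known or untested is meant among the compounds shown, and "the series" means these compounds.

Compound 1, `COc1ccccc1/C=C/C=N/N1C(=S)NC2C1N(C)C(=O)N2c1ccccc1`: 230 nM
Compound 2, `CCN1C(=O)N(CC)C2C1NC(=S)N2/N=C/C=C/c1ccccc1OC`: 86100 nM
Compound 3, `CCN1C(=O)N(c2ccccc2)C2NC(=S)N(/N=C/C=C/c3ccccc3)C21`: 2170 nM

In an ADME assay on HEK293 cells (Homo sapiens) for inhibition, read by MTT assay, with a stated time of 72 h (on this read-out higher numbers stand for weaker inhibition and lower numbers for stronger inhibition), compound 3 stands second highest of the three numbers. Compound 1 sits well below it, a gap beyond the scatter. Compound 2 sits far above it, also beyond the scatter.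

Compound 4, `CCN1C(=O)N(c2ccccc2)C2NC(=S)N(/N=C/C=C/c3ccccc3OC)C21`, differs from compound 3 by methoxy in place of hydrogen on an aromatic carbon. Within the data shown here, no pair measured so far isolates this change: compound 1 and compound 2 both carry the methoxy group, but on differently substituted cores, and their values lie on opposite sides of compound 3. The step is therefore expected to be small, most likely within the scatter, with a slight lean toward a lower number. Compound 4 is estimated at 1300 nM, between 350 nM and 5000 nM, a step of a 1.7-fold lower number from compound 3 to compound 4 (0.22 log units; within the scatter) in this assay.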

Compound 4, half-maximal inhibitory concentration: 57500 nM
Beside the measured number, compound 4's estimate is 44-fold (1.65 log units) below it; measured number above the stated range.
By their numbers in this assay, from the lowest: compound 1; then compound 3; then compounds 4 and 2 (each within the scatter of the next).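

In this assay, methoxy in place of hydrogen on an aromatic carbon, ortho to a large group, proves a large change: a 26-fold higher number from compound 3 to compound 4 (1.42 log units; beyond the scatter). With the methoxy present, phenyl in place of ethyl on an amide-type nitrogen in a ring gives only a 1.5-fold lower number from compound 2 to compound 4 (0.18 log units; within the scatter), whereas methyl in place of hydrogen on a saturated chain carbon bound to that nitrogen gives a 250-fold higher number from compound 1 to compound 4 (2.40 log units; beyond the scatter). Nothing available explains why these steps differ so much.

Going by these compounds, whether hydroxy or fluorine on the same carbon would act like methoxy stays open. So does whether the methoxy step would be as large on the core of compound 1.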